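Trading 3-acetylphenyl for furan-2-yl at a measuring limit

The source may report more compounds than this note shows. Statements on the series, on what has been measured and on what is new or still open speak of the compounds shown alone.

Compound 1 `CC(C)N(Cc1cccc(OCCCCCC(=O)O)c1)C(=O)c1ccc(-c2cccc(N(C)C)c2)cc1` gives > 26000 nM (a limit)
Compound 2 `CC(C)N(Cc1cccc(OCCCCCC(=O)O)c1)C(=O)c1ccc(-c2cccc(-c3ccccc3)c2)cc1` gives > 26000 nM (a limit)
Compound 3 `CC(=O)c1cccc(-c2ccc(C(=O)N(Cc3cccc(OCCCCCC(=O)O)c3)C(C)C)cc2)c1` gives > 26000 nM (a limit)

In an ADME assay on HepG2 cells (Homo sapiens) for cytotoxicity, read by CellTiter-Glo and resazurin assay, with a stated time of 72 h (on this read-out lower numbers stand for an effect already at smaller amounts and higher numbers for an effect only at larger amounts of compound), compound 3 gives > 26000 nM (a limit and not a number). Going by the values given here, the wider picture is the limit of > 26000 nM in this assay, at which 3 of the 3 values shown sit (so no compound can be ranked against another).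

The next step leads to compound 4 `CC(C)N(Cc1cccc(OCCCCCC(=O)O)c1)C(=O)c1ccc(-c2ccco2)cc1`, which carries furan-2-yl in place of 3-acetylphenyl on an aromatic carbon.

Each of three measured steps also exchanges a group on an aromatic carbon (a step that the two limits leave unreadable from compound 1 to compound 3; a step that the two limits leave unreadable from compound 2 to compound 3; a step that the two limits leave unreadable from compound 1 to compound 2), and none of them has a readable size. The expectation therefore rests on compound 3 and its step that the two limits leave unreadable from compound 2 to compound 3 (no size to carry over): no step beyond the scatter is expected in this assay, and no direction can be named. The estimated step is a step that the limit leaves unreadable from compound 3 to compound 4 (expected to stay within the scatter). Another limit, rather than a number, is the likely report. Compound 4 is expected at 30000 nM (estimated range 15000 nM to 60000 nM).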

Compound 4, half-maximal effective concentration: > 26000 nM
Compound 4 gave a limit, no number (the forecaster's own chance of this, stated with the estimate: 85%); the middle value does not contradict the limit.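

No step can be read among compound 1, compound 2, compound 3 and compound 4 in this assay, since each gives only a limit and not a number: the limit of > 26000 nM in this assay, at which 4 of the 4 values shown sit. On these data alone, how far each compound lies from that limit, and whether the exchanged groups differ at all in this read-out, remains open.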